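The compounds below may be only part of what the source reports. "The series", "measured", "known", "first", "only" and "open" are said of these compounds alone.

Series notes. Compound 2 `CNC(=O)[C@H](CCCN)NC(=O)[C@H](CCCc1ccccc1)[C@@](C)(O)C(=O)NO` carries a free amine on its side chain, and in an assay on isolated protein for binding affinity to matrix metalloproteinase-9 (Homo sapiens) (on this read-out lower numbers stand for stronger inhibition and higher numbers for weaker inhibition), compound 2 gives 5 nM. Compound 1 `CNC(=O)[C@H](CCCNC(=O)N1CCOCC1)NC(=O)[C@H](CCCc1ccccc1)[C@@](C)(O)C(=O)NO` carries a (morpholin-4-yl)carbonyl on that same nitrogen, and in this assay compound 1 gives 4 nM. Compound 3 `C[C@@H](NC(=O)[C@H](CCCCN)NC(=O)[C@H](CCCc1ccccc1)[C@@](C)(O)C(=O)NO)c1ccccc1` differs from compound 2 in more than one place, and in this assay compound 3 gives 149 nM. Among the three numbers compound 2 stands second highest: compound 1 is within the scatter of it, while compound 3 lies well beyond the scatter at a far higher number.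

Compound 4 `CNC(=O)[C@H](CCCNC(=O)OC(C)(C)C)NC(=O)[C@H](CCCc1ccccc1)[C@@](C)(O)C(=O)NO` has not yet been measured. Its change from compound 2 is tert-butoxycarbonyl in place of hydrogen on an amine nitrogen. Going by the values given here, the only measured step at this same nitrogen is a 1.3-fold higher number from compound 1 to compound 2 (0.10 log units; within the scatter), which shows that removing a carbonyl-linked cap from the amine left the number within the scatter. Nothing in the measured set distinguishes one such cap from another at this position, so the tert-butoxycarbonyl cap is expected to behave as the (morpholin-4-yl)carbonyl cap did, and the step of a 1.1-fold lower number from compound 2 to compound 4 (0.05 log units; within the scatter) is expected to stay within the scatter. Compound 4 is therefore estimated at 4.5 nM, with an expected range from 1.5 nM to 14 nM.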

Compound 4, inhibition constant: 2 nM
The estimate for compound 4 lay 2.3-fold (0.35 log units) above the measured number; measured number inside the range.
By their numbers in this assay, from the lowest: compounds 4, 1 and 2 (each within the scatter of the next, the first and the last beyond it); then compound 3.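

In this assay, tert-butoxycarbonyl on the amine nitrogen gives a 2.5-fold lower number from compound 2 to compound 4 (0.40 log units; beyond the scatter), a modest step but the first at this nitrogen to lie beyond the scatter, whereas the (morpholin-4-yl)carbonyl cap stayed within the scatter of the free amine. Exchanging one cap for the other gives a 2.0-fold lower number from compound 1 to compound 4 (0.30 log units; within the scatter), which lies within the scatter, so the two caps cannot be told apart directly; only the tert-butoxycarbonyl cap separates from the free amine, and the separation is small. The position therefore accepts a group of this size without any loss in this assay, and no supporting data on the compounds explain the small gain seen with tert-butoxycarbonyl.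

As far as these compounds go, it remains open whether the step belongs to carbonyl-linked caps in general or to tert-butoxycarbonyl alone, as a simple acetyl cap, a benzyloxycarbonyl cap or a methanesulfonyl group on the same nitrogen would show. Also open, from the compounds shown here alone, is how a carboxylic acid at the chain end, or a longer chain carrying the same caps on an otherwise unchanged core, would read in this assay.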